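The source may report more compounds than this note shows. Statements on the series, on what has been measured and on what is new or still open speak of the compounds shown alone.

Compound 1 `CC(C)(C)NC(=O)c1cc(-c2ccc(Cl)cc2Cl)n[nH]1` carries a (tert-butyl)amino group on its amide carbonyl. Among the compounds with values here, in an assay on isolated protein for inhibition of alkaline phosphatase, tissue-nonspecific isozyme (Homo sapiens) (on this read-out higher numbers stand for weaker inhibition and lower numbers for stronger inhibition), compound 1 gives 398 nM, the second highest of the three numbers measured so far. Compound 3 `CN(C)C(=O)c1cc(-c2cc(F)c(Cl)cc2Cl)n[nH]1` differs from compound 1 in two places. In this assay compound 3 gives 324 nM, a value within the scatter of that of compound 1. Compound 2 `CN1CCN(C(=O)c2cc(-c3ccc(Cl)cc3Cl)n[nH]2)CC1` gives 828 nM in this assay. Within the data shown here, the one measured step that changes only the amide substituent is a 2.1-fold higher number from compound 1 to compound 2 (0.32 log units; beyond the scatter), a modest weakening.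

Compound 4 `COCCNC(=O)c1cc(-c2ccc(Cl)cc2Cl)n[nH]1` is made from compound 1 by the change (2-methoxyethyl in place of tert-butyl on an amide-type nitrogen), that is, (tert-butyl)amino becomes (2-methoxyethyl)amino. Among the measured compounds shown here, the step from compound 1 to compound 2 is the only guide, and it shows that swapping the amide substituent moved the number only modestly. Compound 4 is therefore expected to sit near compound 1 in this assay, with a step of about a 1.3-fold higher number from compound 1 to compound 4 (0.10 log units; within the scatter) in the direction of slightly weaker inhibition or none beyond the scatter. The estimate for compound 4 in this assay is 500 nM, expected to fall between 200 nM and 1300 nM.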

Compound 4, half-maximal inhibitory concentration: 46 nM
For compound 4 the middle estimate is 11-fold (1.04 log units) above the measured one; the whole stated range lies above it.
By their numbers in this assay, from the lowest: compound 4; then compounds 3 and 1 (each within the scatter of the next); then compound 2.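

In this assay, the amide substituent proves able to move the number much further than the earlier step suggested: 2-methoxyethyl in place of tert-butyl gives an 8.7-fold lower number from compound 1 to compound 4 (0.94 log units; beyond the scatter), although both groups have 4 heavy atoms and neither has a ring. Against the 4-methylpiperazin-1-yl amide, the (2-methoxyethyl)amino group gives an 18-fold lower number from compound 2 to compound 4 (1.26 log units; beyond the scatter), so this one position spans a wide range with the rest of the molecule unchanged. Nothing available explains why this exchange, which brings in an oxygen and one hydrogen-bond acceptor, goes with stronger inhibition.

Going by these compounds, it remains open whether an all-carbon chain such as butyl would do as well as 2-methoxyethyl, which would show whether the oxygen matters at all. Also open, on these data alone, is how a longer chain such as 3-methoxypropyl or an alcohol such as 2-hydroxyethyl would compare.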